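A few compounds are considered here, and "the series" means these few. Any claim that something is new, unique, unknown or untested is made for them only; others in the source may bear on it.

Measured so far:
compound 1 `COc1ccc(-n2cc(CNCCN3CCN(C)CC3)c(-c3ccccc3C)n2)cc1` — > 20000 nM
compound 2 `Cc1ccccc1-c1nn(-c2cccc(Cl)c2)cc1CNCCN1CCN(C)CC1` — 16000 nM

In an ADME assay on Huh-7 cells (Homo sapiens) for cytotoxicity (a lower number here means that less compound is tolerated, a higher number that more compound is tolerated), compound 1 gives > 20000 nM, which is a limit of the assay rather than a number. Among the measured compounds shown here, compound 2 gives 16000 nM in this assay and is the only compound with a number. The other value shown belongs to compound 1 and is the limit of > 20000 nM in this assay, at which 1 of the 2 values shown sits. For the measured compounds named here, the one measured step, an at least 1.2-fold lower number from compound 1 to compound 2 (0.09 log units; that floor lies within the scatter), lies within the scatter.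

Compound 3 `Cc1ccccc1-c1nn(-c2ccc(N)cc2)cc1CNCCN1CCN(C)CC1` differs from compound 2 by 4-aminophenyl in place of 3-chlorophenyl on an aromatic nitrogen. The measured step bears directly on this change, since it also swaps the aryl group on the same aromatic nitrogen of the shared core. That step was small and within the scatter, so no movement beyond the scatter is expected in this assay for compound 3; a flat step is expected because an at least 1.2-fold lower number from compound 1 to compound 2 (0.09 log units; that floor lies within the scatter) gave no shift that the scatter does not cover. The estimated step is a 1.1-fold higher number from compound 2 to compound 3 (0.05 log units; within the scatter).

Compound 3 is therefore expected to give about 18000 nM in this assay, within a range of 9000 nM to 36000 nM, with a fair chance that only a limit is reported.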

Compound 3, half-maximal cytotoxic concentration: > 20000 nM
Compound 3 gave a limit, no number (the forecaster's own chance of this, stated with the estimate: 40%); at least 1.1-fold (0.04 log units) between middle value and limit.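

In this assay, the change from 3-chlorophenyl to 4-aminophenyl on the aromatic nitrogen gives an at least 1.2-fold higher number from compound 2 to compound 3 (0.09 log units; that floor lies within the scatter), so this position has now taken a group with a hydrogen-bond donor with no step beyond the scatter. Compound 3 gives > 20000 nM, which is a limit and not a number, and the step between the two limits, amino in place of methoxy, cannot be read. With this result, the limit accounts for most of the series: the limit of > 20000 nM in this assay, at which 2 of the 3 values shown sit.

The compounds shown leave open whether any aryl group at this position can produce a step beyond the scatter in this assay, and only compound 2 offers a number to measure such a step from. The exchange from compound 2 to compound 3 alters both the substituent and its place on the phenyl ring, so 4-chlorophenyl or 3-aminophenyl would be needed to separate the two, while a carboxylic acid or a trifluoromethyl group on that ring would test the position with a different kind of substituent.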